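From 3-nitrophenyl to 4-chlorophenyl in a growth-inhibition series

The source may hold more compounds than are shown below. What is called first, only, known or untested is meant among the compounds shown, and "the series" means these compounds.

In a functional assay on HT-29 cells (Homo sapiens) for cytotoxicity, read by sulforhodamine B assay (on this read-out lower numbers stand for stronger inhibition of growth and higher numbers for weaker inhibition of growth), compound 3 `CC1=CC[C@@H]([C@@](C)(O)CCCC(C)(C)NC(=S)N/N=C\c2cccc([N+](=O)[O-])c2)CC1` gives 57100 nM and stands within the scatter of compound 2 `CC1=CC[C@@H]([C@@](C)(O)CCCC(C)(C)NC(=S)N/N=C\c2ccc(C)cc2)CC1` at 80400 nM on the numbers shown. Compound 1 `CC1=CC[C@@H]([C@@](C)(O)CCCC(C)(C)NC(=S)NN)CC1` reads > 100000 nM in this assay and that value is a limit, not a number.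

The change to compound 4 `CC1=CC[C@@H]([C@@](C)(O)CCCC(C)(C)NC(=S)N/N=C\c2ccc(Cl)cc2)CC1` is 4-chlorophenyl in place of 3-nitrophenyl on a carbon with a double bond to nitrogen with 4-chlorophenyl in place of 3-nitrophenyl on a carbon with a double bond to nitrogen. The closest measured step is the exchange at that same place, 3-nitrophenyl in place of 4-methylphenyl, which gave a 1.4-fold lower number from compound 2 to compound 3 (0.15 log units; within the scatter) and stayed within the scatter. The other measured step of an at least 1.2-fold lower number from compound 1 to compound 2 (0.09 log units; that floor lies within the scatter) has a floor that also lies within the scatter and offers little guidance on this exchange.

On that basis, no change beyond the scatter is expected in this assay and no firm direction can be assigned. The expected step is a 1.1-fold higher number from compound 3 to compound 4 (0.02 log units; within the scatter) and it stays small. Compound 4 is estimated at 60000 nM with an expected range of 30000 nM to 100000 nM.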

Compound 4, concentration for total growth inhibition: 22600 nM
For compound 4 the middle estimate is 2.7-fold (0.42 log units) above the measured one, and the stated range ends above it.
By their numbers in this assay, from the lowest: compound 4; then compounds 3 and 2 (each within the scatter of the next). At a limit, above all of these: compound 1.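

In this assay, the position on the carbon with a double bond to nitrogen now gives a step beyond the scatter, a 2.5-fold lower number from compound 3 to compound 4 (0.40 log units; beyond the scatter), whereas the earlier exchange at this place stayed within it. Chloro in place of methyl on an aromatic carbon also reaches beyond the scatter, with a 3.6-fold lower number from compound 2 to compound 4 (0.55 log units; beyond the scatter), so 4-chlorophenyl stands apart from both 3-nitrophenyl and 4-methylphenyl, although compounds 2 and 3 remain within the scatter of each other. The step of an at least 4.4-fold lower number from compound 1 to compound 4 (0.64 log units; beyond the scatter) also lies beyond the scatter, but it is only a floor, as compound 1 stands at a limit: the limit of > 100000 nM in this assay, at which 1 of the 4 values shown sits.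

Going by these compounds, it remains open whether 3-chlorophenyl would read like 4-chlorophenyl, and how a bromo, methoxy or amine group on the same ring would read. The compounds shown also do not tell how a carboxylic acid or a longer chain would read at this place.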